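Series notes: free amine in place of the alkylpiperazine

The compounds below may be only part of what the source reports. "The series", "measured", "known", "first", "only" and "open" are said of these compounds alone.

Compound 2 `CCC(CC)N1CCN(c2nc3c(c(Nc4ccc(C(F)(F)F)cc4)n2)CCN(c2ncccc2C(F)(F)F)CC3)CC1` gives 185 nM in a functional assay on HEK293 cells for antagonist activity at transient receptor potential cation channel subfamily V member 1 (Rattus norvegicus), read by FLIPR and calcium flux; a lower number here means a stronger inhibitor, a higher number a weaker inhibitor. Of the two numbers in hand it is the lowest; its nearest neighbour is compound 3 `CC(=O)NC1CCN(c2nc3c(c(Nc4ccc(C(F)(F)F)cc4)n2)CCN(c2ncccc2C(F)(F)F)CC3)C1`, which gives 410 nM in this assay, so that a 2.2-fold higher number from compound 2 to compound 3 (0.35 log units; beyond the scatter). Compound 1 `NC1CCN(c2nc3c(c(Nc4ccc(C(F)(F)F)cc4)n2)CCN(c2ncccc2C(F)(F)F)CC3)C1` reaches only the limit of > 5000 nM in this assay, which is a limit and not a number (the limit of > 5000 nM in this assay, at which 1 of the 3 values shown sits). From there, an at least 27-fold lower number from compound 1 to compound 2 (1.43 log units; beyond the scatter) and an at least 12-fold lower number from compound 1 to compound 3 (1.08 log units; beyond the scatter).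

Compound 4 `FC(F)(F)c1ccc(Nc2nc(NC3CCCNC3)nc3c2CCN(c2ncccc2C(F)(F)F)CC3)cc1` differs from compound 2 in one place: (piperidin-3-yl)amino in place of 4-(pentan-3-yl)piperazin-1-yl on an aromatic carbon.

Within the data shown here, two measured steps bear on this. Among the measured compounds shown here, compound 1, the only member with a free ring-bound amine, sits at the limit, and acetylation of that amine in compound 3 gave a large step, as did replacing the whole group with 4-(pentan-3-yl)piperazin-1-yl in compound 2. Compound 4 again carries a free ring amine and two donors, so a large step upward in this assay, beyond the scatter, is expected rather than none. The step expected is an 8.1-fold higher number from compound 2 to compound 4 (0.91 log units; beyond the scatter). Compound 4 is accordingly estimated at 1500 nM, with a range from 400 nM to 6000 nM, and a fair chance that only a limit is reported.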

Compound 4, half-maximal inhibitory concentration: > 5000 nM
Compound 4 ended at the assay's limit; the forecaster's own chance of this, stated with the estimate: 30%; middle value at least 3.3-fold (0.52 log units) from the limit.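

The second member with a free ring amine, compound 4, also stops at a limit and not a number in this assay: the limit of > 5000 nM in this assay, at which 2 of the 4 values shown sit. On the aromatic carbon between two ring nitrogen atoms, (piperidin-3-yl)amino gives an at least 27-fold higher number from compound 2 to compound 4 (1.43 log units; beyond the scatter), and set against the 3-acetamidopyrrolidin-1-yl group it gives an at least 12-fold higher number from compound 3 to compound 4 (1.08 log units; beyond the scatter). The earlier compounds tied the limit to 3-aminopyrrolidin-1-yl alone, whereas it now also appears with a six-membered ring joined through an amino group, and among the four compounds shown, the two with a free amine on this ring substituent sit at the limit while compounds 2 and 3, which have none, give numbers.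

The steps between the two compounds at the limit cannot be read, so compounds 1 and 4 cannot be ranked against each other. Also open, from the compounds shown here alone, is whether an acetyl or methyl group on the ring nitrogen of the (piperidin-3-yl)amino group would return a measurable number, as acetyl did in an at least 12-fold lower number from compound 1 to compound 3 (1.08 log units; beyond the scatter), and whether the free amine or the amino link carries the step to compound 4.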